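Restoring a direct aryl link on the shared core

This account rests on a few compounds, and the source may have more. Where it says the series, first, only, none or still open, it means among the compounds named here.

Compound 2 `COc1ccc(OC)c(Sc2ccc3nnc(Cc4cnn(C)c4)n3n2)c1` gives 32000 nM in an assay on isolated protein for inhibition of Leucine-rich repeat serine/threonine-protein kinase 2 (Homo sapiens), in the presence of a further agent that is not named here (a higher number here means a weaker inhibitor, a lower number a stronger inhibitor), the highest of the two numbers at hand; its nearest neighbour is compound 1 `COc1ccc(OC)c(Sc2ccc3nnc(-c4cccnc4)n3n2)c1`, which gives 242 nM in this assay. Within the data shown here, the one measured step between them, a 130-fold higher number from compound 1 to compound 2 (2.12 log units; beyond the scatter), is large and runs in the direction of weaker inhibition. Compound 3 `COc1ccc(OC)c(Sc2ccc3nnc(-c4ccsn4)n3n2)c1` is reached from compound 2 by the change (1,2-thiazol-3-yl in place of (1-methyl-1H-pyrazol-4-yl)methyl on an aromatic carbon). This change bears directly on that single step: the methylene-linked group that entered from compound 1 to compound 2 leaves again, and a five-membered aromatic ring bound directly to the core enters, which brings compound 3 closer in shape to compound 1 than to compound 2. Among the measured compounds shown here, on that basis the step from compound 2 to compound 3 in this assay is expected to be a large fall in the number, a 46-fold lower number from compound 2 to compound 3 (1.66 log units; beyond the scatter), though with only one measured step as a guide it is estimated to stop short of the level of compound 1. Compound 3 is therefore expected to give about 700 nM in this assay, within a range of 150 nM to 3500 nM.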

Compound 3, half-maximal inhibitory concentration: 91 nM
Beside the measured number, compound 3's estimate is 7.7-fold (0.89 log units) above it, outside the stated range (below it).
By their numbers in this assay, from the lowest: compound 3; then compound 1; then compound 2.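

In this assay, putting 1,2-thiazol-3-yl in place of (1-methyl-1H-pyrazol-4-yl)methyl on this aromatic carbon gives a 350-fold lower number from compound 2 to compound 3 (2.55 log units; beyond the scatter) and so takes the number to the lowest of the three compounds. The directly bound pyridin-3-yl of compound 1 therefore does not mark the best value at this position, since 1,2-thiazol-3-yl in its place gives a 2.7-fold lower number from compound 1 to compound 3 (0.42 log units; beyond the scatter), a modest but real step. The leaving and entering groups each hold one five-membered aromatic ring with 2 hetero atoms and have the same counts of hydrogen-bond donors and acceptors, so those counts do not separate the two compounds, and the large step from compound 2 combines the change of ring with the loss of the methylene link.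

No measurement at hand accounts for either step. The compounds shown leave open how much of the large step belongs to the link alone, which a 1-methyl-1H-pyrazol-4-yl group bound directly to the core would address, and whether a plain phenyl ring, or a ring carrying an amine or a carboxylic acid, would be tolerated at this position.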